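Replacing the quinolinyl ether in the aspartyl ketone series

This account rests on a few compounds, and the source may have more. Where it says the series, first, only, none or still open, it means among the compounds named here.

Compound 1 `CC(C)[C@H](NC(=O)COc1cccc2ccccc12)C(=O)N[C@@H](CC(=O)O)C(=O)CSc1nc2ccccc2o1` and compound 2 `CC(C)[C@H](NC(=O)COc1cccc2ccccc12)C(=O)N[C@@H](CC(=O)O)C(=O)COc1ccc2ccccc2n1` share one core and differ only in the aryl ether group. In a functional assay on Jurkat cells (Homo sapiens) for inhibition (on this read-out lower numbers stand for stronger inhibition and higher numbers for weaker inhibition), compound 1 gives only the assay limit > 200000 nM. In this assay compound 2 likewise gives only the limit > 200000 nM. The step that the two limits leave unreadable from compound 1 to compound 2 is therefore unreadable, both values sitting at the limit of > 200000 nM in this assay, at which 2 of the 2 values shown sit. Compound 3 `CC(C)[C@H](NC(=O)COc1cccc2ccccc12)C(=O)N[C@@H](CC(=O)O)C(=O)COc1[nH]cnc2nncc1-2` carries a group of 9 heavy atoms (5 carbon, 4 nitrogen; one five-membered aromatic ring with 2 hetero atoms, one six-membered aromatic ring with 2 hetero atoms) in place of a group of 10 heavy atoms (9 carbon, 1 nitrogen; one six-membered aromatic ring of carbon only, one six-membered aromatic ring with 1 hetero atom), on an oxygen on a saturated carbon. Going by the values given here, no measured step bears readably on this change; since compound 2 stands at the limit, the step that the limit leaves unreadable from compound 2 to compound 3 is an expectation only, with a further limit likely. Compound 3 is estimated at 300000 nM, range 50000 nM to 2000000 nM.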

Compound 3, half-maximal inhibitory concentration: 161000 nM
Estimate against measurement, compound 3: 1.9-fold (0.27 log units) above, within the range that was stated.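

In this assay, going by these compounds alone, compound 3 gives 161000 nM, the first value at this position that is a number and not a limit. The replacement reads as an at least 1.2-fold lower number from compound 2 to compound 3 (0.09 log units; that floor lies within the scatter), and the change to the group on the saturated chain carbon bound to a carbonyl carbon reads as an at least 1.2-fold lower number from compound 1 to compound 3 (0.09 log units; that floor lies within the scatter). The other values remain limits: the limit of > 200000 nM in this assay, at which 2 of the 3 values shown sit.

Going by these compounds, the true size of both steps stays open, as each is only a floor. Also open, on these data alone, is how an amine or a phenyl group in place of the group of compound 3 would read.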